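Lengthening the Chain on the Ring Nitrogen

The source may hold more compounds than are shown below. What is called first, only, known or untested is meant among the compounds shown, and "the series" means these compounds.

In an assay on HEK293 cells for positive allosteric modulation of metabotropic glutamate receptor 2 (Rattus norvegicus), read by thallium flux (on this read-out lower numbers stand for an effect already at smaller amounts and higher numbers for an effect only at larger amounts of compound), compound 2 `O=C(O)c1cc(-c2cccc(COc3ccc4c(=O)n(CC5CC5)sc4c3)c2)ccc1Cl` gives 2480 nM, the highest number among the three measured compounds. Compound 1 `Cn1sc2cc(OCc3cccc(-c4ccc(Cl)c(C(=O)O)c4)c3)ccc2c1=O` gives 640 nM, and compound 3 `O=C(O)c1cc(-c2cccc(COc3ccc4c(c3)CN(C3CCCC3)C4=O)c2)ccc1O`, which carries a different core, gives 20 nM. Compound 4 `CC(C)CCn1sc2cc(OCc3cccc(-c4ccc(Cl)c(C(=O)O)c4)c3)ccc2c1=O` is not yet measured; it differs from compound 2 by isobutyl in place of cyclopropyl on a saturated chain carbon bound to an aromatic nitrogen. Going by the values given here, the only measured step at this position is a 3.9-fold higher number from compound 1 to compound 2 (0.59 log units; beyond the scatter), where a ring group replaced hydrogen and the number rose. The present change again enlarges the group at that position, but from a different starting point, so its direction is uncertain. For compound 4 the expected step is a 1.4-fold higher number from compound 2 to compound 4 (0.15 log units; within the scatter), a small rise or none beyond the scatter. Compound 4 is therefore estimated at 3500 nM, within a range from 1200 nM to 10000 nM.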

Compound 4, half-maximal effective concentration: 650 nM
For compound 4 the middle estimate is 5.4-fold (0.73 log units) above the measured one; the whole stated range lies above it.
By their numbers in this assay, from the lowest: compound 3; then compounds 1 and 4 (each within the scatter of the next); then compound 2.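

Isobutyl in place of cyclopropyl gives a 3.8-fold lower number from compound 2 to compound 4 (0.58 log units; beyond the scatter), so a larger group on this carbon does not by itself raise the number. Isobutyl in place of hydrogen on the same carbon gives a 1.0-fold higher number from compound 1 to compound 4 (0.01 log units; within the scatter), which means that among compounds 1, 2 and 4 only the cyclopropyl group goes with a rise. Nothing available explains why the ring and the open chain differ. From the compounds shown here alone, it remains open whether a longer chain than isopentyl, or a chain ending in an amine, would keep the number this low. Going by these compounds, whether isopentyl behaves the same way on the core of compound 3 is also open.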